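This account rests on a few compounds, and the source may have more. Where it says the series, first, only, none or still open, it means among the compounds named here.

Measured compounds:
compound 1 `O=C(Nc1cccc(-n2cc(-c3ccncc3)c(-c3cc(O)cc(Cl)c3)n2)c1)Nc1ccc(Cl)c(C(F)(F)F)c1` — 53%
compound 2 `O=C(Nc1cccc(-n2cc(-c3ccncc3)c(-c3cc(O)cc(Cl)c3)n2)c1)Nc1ccc(Cl)c(Cl)c1` — 96%

In a functional assay on T47D cells (Homo sapiens) for inhibition, read by sulforhodamine B assay, with a stated time of 48 h, tested at 1 uM (a lower number here means a stronger effect, a higher number a weaker effect of the compound at the concentration tested), compound 1 gives 53%, the lowest of the two numbers shown, while compound 2 gives 96%. Going by the values given here, the only measured step, a number 43 percentage points higher from compound 1 to compound 2 (beyond the scatter), exchanges chloro for trifluoromethyl on an aromatic carbon and lies beyond the scatter. Compound 3 `COc1cc(Cl)cc(-c2nn(-c3cccc(NC(=O)Nc4ccc(Cl)c(C(F)(F)F)c4)c3)cc2-c2ccncc2)c1` differs from compound 1 by methyl in place of hydrogen on an oxygen on an aromatic ring. The methyl enters on an oxygen on an aromatic ring whose other neighbour is an aromatic carbon, a place the measured step does not touch, so that step does not bear on the change to compound 3. Among the compounds with values here, no measured pair shows what hydroxy to methoxy does in this assay, and the direction of the step remains open. Compound 3 is therefore estimated at 66%, within 40% to 92%, which would be an expected step of a number 13 percentage points higher from compound 1 to compound 3 (beyond the scatter).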

Compound 3, a percentage reported as activity, at one concentration (the size of the read-out at that concentration, not a potency): 58%
The estimate for compound 3 lay 8 percentage points above the measured number; measured number inside the range.
By their numbers in this assay, from the lowest: compounds 1 and 3 (each within the scatter of the next); then compound 2.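

In this assay, going by these compounds alone, the step from hydroxy to methoxy, a number 5 percentage points higher from compound 1 to compound 3 (within the scatter), leaves the two numbers indistinguishable, which is the first reading of this position. At this one concentration, then, a hydrogen on this oxygen is not required for a read-out of the size seen with compound 1, and methyl can stand in its place. No measurement at hand bears on why these two compounds read alike.

The compounds shown leave open whether a longer chain on this oxygen, such as ethoxy, or a chain ending in an amine or a carboxylic acid would read the same. They also leave open whether methoxy would give the same result with chloro in place of trifluoromethyl, as in compound 2, and how compound 1 and compound 3 compare at other concentrations.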